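One Methyl on an Aromatic Nitrogen, Two Cores

The source may report more compounds than this note shows. Statements on the series, on what has been measured and on what is new or still open speak of the compounds shown alone.

Of the compounds shown here, three have so far been measured in a functional assay on KB403 cells (Homo sapiens) for cytotoxicity, read by MTT assay, with stated times of 6 h and 48 h; on this read-out lower numbers stand for stronger inhibition and higher numbers for weaker inhibition. Compound 1 `COc1ccc(C(=O)/C=C/c2cc(Br)c(Br)n2C)c(OC)c1` and compound 2 `COc1ccc(C(=O)/C=C/c2cc(Br)c(Br)[nH]2)c(OC)c1` share one core, while compound 3 `O=c1cc(-c2cc(Br)c(Br)[nH]2)oc2ccccc12` carries another, and the difference between the two cores is not broken down here. Compound 4 `Cn1c(-c2cc(=O)c3ccccc3o2)cc(Br)c1Br` has not yet been measured.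

In this assay compound 1 returns only a limit, >= 100000 nM. In this assay compound 2 likewise returns only a limit, >= 100000 nM. Among the compounds with values here, compound 3 gives 1280 nM in this assay, the only number among the three.

Compound 1 differs from compound 2 by methyl in place of hydrogen on an aromatic nitrogen. Since both of these values sit at the limit of >= 100000 nM in this assay, at which 2 of the 3 values shown sit, the step that the two limits leave unreadable from compound 2 to compound 1 cannot be read.

Compound 4 differs from compound 3 by methyl in place of hydrogen on an aromatic nitrogen, the same change at the same place. Beside that earlier unreadable step, compound 4 is expected to show a step of a 2.3-fold higher number from compound 3 to compound 4 (0.37 log units; beyond the scatter) in this assay. This expectation rests only on compound 3 and its value of 1280 nM, as the earlier pair gives no direction. Compound 4 is therefore estimated at 3000 nM in this assay, within 700 nM to 25000 nM.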

Compound 4, half-maximal inhibitory concentration: 670 nM
Compound 4: the middle estimate sits 4.5-fold (0.65 log units) above what was measured; measured number outside the range, below it.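

In this assay methyl in place of hydrogen on an aromatic nitrogen gives a 1.9-fold lower number from compound 3 to compound 4 (0.28 log units; within the scatter) and so, on the core of compound 3, the two values lie within the scatter of each other. This one readable pair shows that the methyl can be carried onto this core with the value remaining within the scatter of the value for the hydrogen, but it does not establish that the change acts alike on both cores. No comparison between the cores can be drawn, because the same change on the core of compound 2 cannot be read: the limit of >= 100000 nM in this assay, at which 2 of the 4 values shown sit.

The compounds shown leave open how a longer chain on that aromatic nitrogen, or a chain ending in an amine or a carboxylic acid, would read in this assay. They also leave open whether the result for the methyl would hold with another group in place of either bromo group.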